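Aryl ketone variation on a fused thiadiazine series

The compounds below may be only part of what the source reports. "The series", "measured", "known", "first", "only" and "open" are said of these compounds alone.

Measured so far:
compound 1 `COc1cc(C(=O)C2Sc3nnc(-c4cc(OC)c(OC)c(OC)c4)n3NC2c2ccco2)cc(OC)c1OC`: 48300 nM
compound 2 `COc1cc(-c2nnc3n2NC(c2ccco2)C(C(=O)c2ccc(F)cc2)S3)cc(OC)c1OC`: 53700 nM
compound 3 `COc1cc(-c2nnc3n2NC(c2ccco2)C(C(=O)c2ccc(-c4ccccc4)cc2)S3)cc(OC)c1OC`: > 100000 nM

The shared core carries a 3,4,5-trimethoxyphenyl on the triazole and a furanyl on the saturated ring; the three compounds differ only in the aryl group on the carbonyl carbon. In a functional assay on A549 cells (Homo sapiens) for cytotoxicity, read by MTT assay, with a stated time of 48 h (on this read-out lower numbers stand for stronger inhibition and higher numbers for weaker inhibition), compound 1 gives 48300 nM and compound 2 gives 53700 nM, and the step of a 1.1-fold higher number from compound 1 to compound 2 (0.05 log units; within the scatter) stays within the scatter. For compound 3 the assay reports only a limit, > 100000 nM, so compound 3 stands at the weak end of what is shown (the limit of > 100000 nM in this assay, at which 1 of the 3 values shown sits). The steps of an at least 2.0-fold higher number from compound 1 to compound 3 (0.31 log units; beyond the scatter) and an at least 1.8-fold higher number from compound 2 to compound 3 (0.27 log units; that floor lies within the scatter) both point the same way, towards a higher number for the 4-phenylphenyl ketone.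

Compound 4 `COc1cccc(C(=O)C2Sc3nnc(-c4cc(OC)c(OC)c(OC)c4)n3NC2c2ccco2)c1` is to be measured in this assay. The change from compound 3 is 3-methoxyphenyl in place of 4-phenylphenyl on a carbonyl carbon. The single-ring aryl ketones, compound 1 and compound 2, both sit near the middle of the measured range, so the expected step of an at least 1.8-fold lower number from compound 3 to compound 4 (0.25 log units; that floor lies within the scatter) is a return to numbers of that order. Compound 4 is therefore expected to give about 55000 nM, within 25000 nM to 120000 nM.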

Compound 4, half-maximal inhibitory concentration: > 100000 nM
Compound 4: a limit, no number; the forecaster's own chance of this, stated with the estimate: 30%; middle value at least 1.8-fold (0.25 log units) from the limit.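

In this assay compound 4 gives only a limit (> 100000 nM), so a single aromatic ring on the carbonyl carbon does not by itself keep a readable number at this position, and the second ring of the 4-phenylphenyl in compound 3 is not needed to reach this end of the scale: the limit of > 100000 nM in this assay, at which 2 of the 4 values shown sit. The 3-methoxyphenyl gives an at least 1.8-fold higher number from compound 2 to compound 4 (0.27 log units; that floor lies within the scatter) and an at least 2.0-fold higher number from compound 1 to compound 4 (0.31 log units; beyond the scatter) so the 3,4,5-trimethoxyphenyl of compound 1 keeps a number where the 3-methoxyphenyl does not. The step between compound 3 and compound 4 cannot be read, both values being limits.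

From the compounds shown here alone, how far compound 3 and compound 4 lie past their limits stays open, as does any order between them. Also open, going by these compounds, is whether an amine or a carboxylic acid on the aryl ring of the ketone would bring the number below that of compound 1.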